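The compounds below may be only part of what the source reports. "The series", "measured", "known", "first", "only" and "open" are said of these compounds alone.

Measured compounds:
compound 1, `Cc1ccc(-c2cn(-c3ccnc4cc(Cl)ccc34)nn2)cc1`, 352000 nM
compound 2, `CCc1ccccc1C(=O)OCc1cn(-c2ccnc3cc(Cl)ccc23)nn1`, > 2550000 nM

Among the measured compounds shown here, in an ADME assay on HepG2 cells (Homo sapiens) for cytotoxicity, read by MTT assay, with a stated time of 24 h (a higher number here means that more compound is tolerated, a lower number that less compound is tolerated), compound 1 gives 352000 nM, and this is the only plain number among the two values known. For compound 2 the result is a limit of the assay, > 2550000 nM. For the measured compounds named here, compound 1 therefore stands alone as the one compound with a numerical reading in this assay, while the other reading sits at the limit of > 2550000 nM in this assay, at which 1 of the 2 values shown sits. Compound 3, `OC1CCN(Cc2cn(-c3ccnc4cc(Cl)ccc34)nn2)CC1`, has not yet been measured in this assay. It differs from compound 1 in one place: (4-hydroxypiperidin-1-yl)methyl in place of 4-methylphenyl on an aromatic carbon. Going by the values given here, no measured pair that differs in a single place is available here, so the size of this step rests on expectation alone rather than on a recorded step. Compound 3 is expected to be tolerated somewhat better than compound 1, with a step of a 2.3-fold higher number from compound 1 to compound 3 (0.36 log units; beyond the scatter) in this assay that goes beyond the usual scatter but not far. Compound 3 is estimated at 800000 nM, with a range from 300000 nM to 2500000 nM.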

Compound 3, half-maximal cytotoxic concentration: 930000 nM
Estimate against measurement, compound 3: 1.2-fold (0.07 log units) below; the measured number falls inside the stated range.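

Among the compounds shown here, the change gives the first recorded step at this position, on an aromatic carbon of the five-membered aromatic ring with 3 nitrogen: in this assay, (4-hydroxypiperidin-1-yl)methyl in place of 4-methylphenyl gives a 2.6-fold higher number from compound 1 to compound 3 (0.42 log units; beyond the scatter), a modest move beyond the scatter. The position thus accepts two quite different groups while both compounds keep plain numbers, a six-membered aromatic ring of carbon only on one side and a six-membered non-aromatic ring with 1 hetero atom on the other. Ring type, hetero atoms, the hydrogen-bond donor and the acceptors all change together in this single step. The step cannot be divided among them, and nothing shown gives a measured cause for it.

The compounds shown leave open whether the hydroxyl group, the ring nitrogen or the loss of the aromatic ring accounts for the step. A plain piperidin-1-ylmethyl group, a morpholin-4-ylmethyl group or a benzyl group at this position would begin to separate these features.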